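Benzylamide in place of ethylamide on a thiophene ester scaffold

The compounds below may be only part of what the source reports. "The series", "measured", "known", "first", "only" and "open" are said of these compounds alone.

Measured compounds:
Compound 1, `COc1ccc(-c2csc(N)c2C(=O)OCc2ccccc2C)cc1OC`: 64%
Compound 2, `CCNC(=O)c1c(-c2ccc(OC)c(OC)c2)csc1N`: 50%

Going by the values given here, in an assay on isolated protein for inhibition of protein kinase C zeta type (Homo sapiens), with stated times of 1 h and 2.5 min, tested at 30 uM (on this read-out higher numbers stand for more inhibition at the one concentration tested (going by the name of the read-out) and lower numbers for less inhibition), compound 2 gives the lower of the two values so far, and compound 1 gives the higher. Among the compounds with values here, the only measured step, a number 14 percentage points lower from compound 1 to compound 2 (beyond the scatter), replaced a benzyl-type ester with a small ethylamide and cost inhibition beyond the scatter.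

Compound 3, `COc1ccc(-c2csc(N)c2C(=O)NCc2ccccc2)cc1OC`, has not yet been measured. It differs from compound 2 by phenyl in place of methyl on a saturated chain carbon bound to an amide-type nitrogen, so that the amide now carries a benzyl group rather than an ethyl group, bringing back an aromatic ring of the kind that compound 1 carries on its ester side.

Because a number 14 percentage points lower from compound 1 to compound 2 (beyond the scatter) showed that shortening the benzyl-type group to ethyl lowered inhibition, restoring a ring is expected to recover part of that loss; the step of a number 8 percentage points higher from compound 2 to compound 3 (within the scatter) is therefore expected to be a modest rise, though it may stay within the scatter. Compound 3 is estimated at 58%, with a range from 42% to 74%.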

Compound 3, a percentage reported as inhibition, at one concentration (the size of the read-out at that concentration, not a potency): 43%
For compound 3 the middle estimate is 15 percentage points above the measured one; the range from low to high includes it.
By their numbers in this assay, from the lowest: compounds 3 and 2 (each within the scatter of the next); then compound 1.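

In this assay, the step of a number 7 percentage points lower from compound 2 to compound 3 (within the scatter) means that swapping ethyl for benzyl on the amide nitrogen gives no readable change, so at this position a phenyl ring on the chain does not by itself restore the inhibition seen with the ester. The step of a number 21 percentage points lower from compound 1 to compound 3 (beyond the scatter) shows that compound 1 and compound 3 are still apart even though both carry a ring, which leaves the change from (2-methylbenzyl)oxy to benzylamino as the difference, and that change alters both the link to the carbonyl and the methyl on the ring. Nothing measured here explains either step.

The compounds shown cannot say which of those two features matters. A plain benzyl ester and a 2-methylbenzyl amide would separate them, while a longer chain such as phenethyl on the amide nitrogen would test how far the ring can sit from the carbonyl.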